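The compounds below may be only part of what the source reports. "The series", "measured", "known", "first", "only" and "open" are said of these compounds alone.

In a functional assay on HCT-116 cells (Homo sapiens) for inhibition, read by colorimetric assay, with a stated time of 3 days (on this read-out lower numbers stand for stronger inhibition and higher numbers for weaker inhibition), compound 2 (`O=C(CCCCCCNC(=O)C(O)(O)C(F)(F)F)Nc1nc2ccccc2s1`) has the lower of the two numbers at 2370 nM, and compound 1 (`O=C(CCCCCCNC(=O)C(O)(O)C(F)(F)F)Nc1nc2ccc(Br)cc2s1`) gives 10300 nM. Compound 3 (`COc1ccc2nc(NC(=O)CCCCCCNC(=O)C(O)(O)C(F)(F)F)sc2c1`) differs from compound 2 by methoxy in place of hydrogen on an aromatic carbon. Within the data shown here, only one measured step bears on this change: a 4.3-fold lower number from compound 1 to compound 2 (0.64 log units; beyond the scatter), a modest step beyond the scatter, with hydrogen in place of bromo. Methoxy is not bromo, so the read-across is loose, but a modest rise in this assay is expected. The expected step is a 1.7-fold higher number from compound 2 to compound 3 (0.23 log units; within the scatter). For compound 3 the estimate is 4000 nM, with a range of 1500 nM to 11000 nM.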

Compound 3, half-maximal inhibitory concentration: 7560 nM
For compound 3 the middle estimate is 1.9-fold (0.28 log units) below the measured one; low and high end bracket the measured number.
By their numbers in this assay, from the lowest: compound 2; then compounds 3 and 1 (each within the scatter of the next).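

In this assay, this position now shows a second group that gives a higher number than hydrogen, with a 3.2-fold higher number from compound 2 to compound 3 (0.50 log units; beyond the scatter). Methoxy and bromo are not separated here, with a 1.4-fold lower number from compound 1 to compound 3 (0.13 log units; within the scatter), so hydrogen in compound 2 remains ahead of both groups. Nothing on hand explains this pattern. Still open, as far as these compounds go, is whether an amine or a carboxylic acid on this aromatic carbon would also give a higher number than hydrogen, and whether methoxy would give the same step on another carbon of the ring.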